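The compounds below may be only part of what the source reports. "The series", "measured", "known", "first", "only" and "open" are said of these compounds alone.

Compound 1 `CN(CCCn1c(=O)sc2ccccc21)Cc1ccccc1` gives 10.3 nM in an assay on Jurkat cells for displacement of a labelled ligand from Sigma non-opioid intracellular receptor 1 (Homo sapiens), read by scintillation counting, with a stated time of 120 min (on this read-out lower numbers stand for stronger inhibition and higher numbers for weaker inhibition), the higher of the two numbers recorded so far. Compound 2 `CN(CCCn1c(=O)sc2ccc(Br)cc21)Cc1ccccc1` gives 3.1 nM in this assay, and the step of a 3.3-fold lower number from compound 1 to compound 2 (0.52 log units; beyond the scatter) follows from bromo in place of hydrogen on an aromatic carbon. Compound 3 `CN(CCCn1c(=O)sc2cc(Br)ccc21)Cc1ccccc1` has not yet been measured in this assay. It differs from compound 1 by bromo in place of hydrogen on an aromatic carbon. Within the data shown here, the only measured step that bears on this change is a 3.3-fold lower number from compound 1 to compound 2 (0.52 log units; beyond the scatter), also a bromo entering the same core, though the bromo of compound 2 and that of compound 3 do not sit on the same carbon. A lower number is therefore expected for compound 3, but with less confidence in its size than for compound 2. A step of about a 2.1-fold lower number from compound 1 to compound 3 (0.31 log units; beyond the scatter) is expected. Compound 3 is estimated at 5 nM, with a range from 2 nM to 13 nM.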

Compound 3, inhibition constant: 0.6 nM
Beside the measured number, compound 3's estimate is 8.3-fold (0.92 log units) above it, outside the stated range (below it).
By their numbers in this assay, from the lowest: compound 3; then compound 2; then compound 1.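

Placed on this aromatic carbon, meta to a fused ring and para to a fused ring, bromo gives a 17-fold lower number from compound 1 to compound 3 (1.23 log units; beyond the scatter) in this assay. This is a large step, whereas the same group on another carbon of that ring gave only a modest one, a 3.3-fold lower number from compound 1 to compound 2 (0.52 log units; beyond the scatter). The earlier compounds shown here showed that bromo could lower the number; compound 3 shows that the size of the step depends on which carbon carries it. Nothing measured here explains this difference between the two carbons.

The compounds shown leave open whether a chloro, a methoxy or a nitrile on this same carbon would match bromo. They also leave open how a longer chain in place of the propyl linker of the core would behave with this bromo in place.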